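Cinnamamide quinolines at melanin-concentrating hormone receptor 1

The compounds below may be only part of what the source reports. "The series", "measured", "known", "first", "only" and "open" are said of these compounds alone.

Measured compounds:
Compound 1 `Nc1cc(C2CCCC2)nc2ccc(NC(=O)/C=C/c3ccc(C(F)(F)F)cc3)cc12`: 0.8 nM
Compound 2 `CCCc1cc(NC2CCC2)c2cc(NC(=O)/C=C/c3ccc(C(F)(F)F)cc3)ccc2n1`: 18 nM

In an assay on isolated protein for displacement of a labelled ligand from melanin-concentrating hormone receptor 1 (Homo sapiens) (a lower number here means a stronger inhibitor, a higher number a weaker inhibitor), compound 2 gives 18 nM, the higher of the two numbers; compound 1 gives 0.8 nM, and the two differ at several places at once, so their gap tells nothing about a single change. Compound 3 `CCCc1cc(N2CCCC2)c2cc(NC(=O)/C=C/c3ccc(C(F)(F)F)cc3)ccc2n1` arises from compound 2 by pyrrolidin-1-yl in place of cyclobutylamino on an aromatic carbon. Among the compounds with values here, no comparable step has been measured here, so the writer expects a step of a 1.7-fold higher number from compound 2 to compound 3 (0.22 log units; within the scatter) that stays close to the scatter, leaning toward a weaker number. For compound 3 the estimate is 30 nM, within 8 nM to 120 nM.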

Compound 3, half-maximal inhibitory concentration: 17 nM
Compound 3: the middle estimate sits 1.8-fold (0.25 log units) above what was measured; measured number inside the range.
By their numbers in this assay, from the lowest: compound 1; then compounds 3 and 2 (each within the scatter of the next).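

Within the data shown here, at the aromatic carbon opposite the ring nitrogen, pyrrolidin-1-yl in place of cyclobutylamino gives a 1.1-fold lower number from compound 2 to compound 3 (0.02 log units; within the scatter) in this assay, the first single-place comparison at this position. In this one pair, losing the hydrogen-bond donor of cyclobutylamino, with the heavy-atom count unchanged, leaves the two numbers within the scatter of each other. Nothing at hand accounts for this result. The compounds shown leave open whether a piperidine or a morpholine on this carbon would read the same, and whether the same holds with a group other than propyl on the ring.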